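This account rests on a few compounds, and the source may have more. Where it says the series, first, only, none or still open, it means among the compounds named here.

- Compound 1 `Cc1cc(-c2ccc(C#N)c(C#N)c2)ccc1Oc1cc(N)nc(Nc2ccc(C#N)cc2)n1`: 76700 nM
- Compound 2 `Cc1cc(-c2ccccc2Cl)cc(C)c1Oc1cc(N)nc(Nc2ccc(C#N)cc2)n1`: 25100 nM

In a toxicity assay on MT4 cells (Homo sapiens) for cytotoxicity, read by MTT assay (on this read-out lower numbers stand for higher toxicity in this test and higher numbers for lower toxicity in this test), compound 2 has the lower of the two numbers at 25100 nM, and its gap to compound 1 lies beyond the usual scatter. Compound 3 `COc1cccc(-c2cc(C)c(Oc3cc(N)nc(Nc4ccc(C#N)cc4)n3)c(C)c2)c1` has not yet been measured. It keeps the rest of compound 2 but carries 3-methoxyphenyl in place of 2-chlorophenyl on an aromatic carbon. Among the compounds with values here, no measured pair isolates this change, so the data offer no direct guide to its size. Both measured compounds show high numbers, which suggests a modest effect at most. In this assay, the estimated step is a 1.2-fold higher number from compound 2 to compound 3 (0.08 log units; within the scatter), so no shift beyond the scatter is expected. For compound 3 the expected value is 30000 nM, with an estimated range from 10000 nM to 90000 nM.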

Compound 3, half-maximal cytotoxic concentration: 19300 nM
The estimate for compound 3 lay 1.6-fold (0.19 log units) above the measured number; measured number inside the range.
By their numbers in this assay, from the lowest: compounds 3 and 2 (each within the scatter of the next); then compound 1.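

In this assay, within the data shown here, putting 3-methoxyphenyl in place of 2-chlorophenyl on this aromatic carbon, para to a large group, gives a 1.3-fold lower number from compound 2 to compound 3 (0.11 log units; within the scatter), and this is the only measured pair that isolates a change at this position. The exchange moves the chlorine-bearing ring out and brings in a methoxy-bearing ring with a hydrogen-bond acceptor, yet compound 2 and compound 3 stay within the scatter of each other on this read-out. No supporting data bear on the reason for this outcome.

As far as these compounds go, whether an amine or a carboxylic acid on this phenyl ring would carry the number beyond the scatter remains open. Compound 1 differs from compound 2 and compound 3 in more than one place, so what sets it apart from them cannot be assigned to any single change.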